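Loosening a Methyl from the Phenol Oxygen

This account rests on a few compounds, and the source may have more. Where it says the series, first, only, none or still open, it means among the compounds named here.

Compound 1 `O=C(Nc1cccc(-n2cc(-c3ccncc3)c(-c3ccc(Cl)c(O)c3)n2)c1)Nc1cccc(C(F)(F)F)c1`: 1640 nM
Compound 2 `COc1cc(-c2nn(-c3cccc(NC(=O)Nc4cc(C(F)(F)F)cc(C(F)(F)F)c4)c3)cc2-c2ccncc2)ccc1Cl`: 826 nM

Of the compounds shown here, two sharing the same core have been measured in a functional assay on IGROV-1 cells (Homo sapiens) for inhibition, read by sulforhodamine B assay, with a stated time of 48 h; a higher number here means a weaker inhibitor of growth, a lower number a stronger inhibitor of growth. Compound 2 gives 826 nM and compound 1 gives 1640 nM; the gap between them lies within the usual scatter of repeated measurements, so the two cannot be told apart on these numbers alone.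

Compound 3 `O=C(Nc1cccc(-n2cc(-c3ccncc3)c(-c3ccc(Cl)c(O)c3)n2)c1)Nc1cc(C(F)(F)F)cc(C(F)(F)F)c1` is the next member. It carries the same two trifluoromethyl groups as compound 2 and differs from it only by hydrogen in place of methyl on an oxygen on an aromatic ring, giving 4-chloro-3-hydroxyphenyl in place of 4-chloro-3-methoxyphenyl. Within the data shown here, no measured pair isolates this single change, so no step size can be read off. Compound 3 is expected to stay close to compound 2 in this assay, with a step of a 1.2-fold higher number from compound 2 to compound 3 (0.08 log units; within the scatter) that is expected to remain near the scatter. The estimate for compound 3 is 1000 nM, within 400 nM to 2500 nM.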

Compound 3, concentration for 50% growth inhibition: 896 nM
Compound 3: middle estimate off by 1.1-fold (0.05 log units), on the high side; low and high end bracket the measured number.
By their numbers in this assay, from the lowest: compounds 2, 3 and 1 (each within the scatter of the next).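

In this assay, among these compounds, hydrogen in place of methyl on the oxygen gives a 1.1-fold higher number from compound 2 to compound 3 (0.04 log units; within the scatter), the first direct reading of this change. With both trifluoromethyl groups present, methoxy and hydroxy at this position therefore cannot be told apart. A second single change, trifluoromethyl in place of hydrogen on an aromatic carbon, gives a 1.8-fold lower number from compound 1 to compound 3 (0.26 log units; within the scatter), so it cannot be told apart from no change either, and no measurement at hand offers an explanation for these small steps.

Going by these compounds, it remains open whether a different group on this ring position, such as a longer ethoxy chain or an amine in place of the hydroxy, would move the number beyond the scatter. On these data alone, it is also open whether methoxy and hydroxy would stay this close in other cell lines.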